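Urea in place of thiourea on the anilinic series

The source may report more compounds than this note shows. Statements on the series, on what has been measured and on what is new or still open speak of the compounds shown alone.

Of the compounds shown here, two have a number so far. Compound 1 `CCNC(=O)NCCC(O)c1ccccc1N` gives 18.3% in an assay for inhibition of Nitric oxide synthase, inducible (Homo sapiens), read by scintillation counting, with a stated time of 30 min, tested at 1 mM; on this read-out lower numbers stand for less inhibition and higher numbers for more inhibition at the one concentration tested (going by the name of the read-out). Compound 2 `CCCNC(=S)NCCC(O)c1cc(OC)ccc1N` gives 25.4% in this assay, the higher of the two numbers, with compound 1 as its nearest neighbour; the gap between them lies within the scatter, so the two cannot be ordered. Going by the values given here, no pair differing in a single place has been measured, and compound 1 and compound 2 differ in more than one place, so the effect of any single change remains unmeasured.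

Compound 3 `CCNC(=O)NCCC(O)c1cc(OC)ccc1N` follows from compound 2 by the change (a group of 5 heavy atoms (3 carbon, 1 nitrogen, 1 oxygen; no ring) in place of a group of 6 heavy atoms (4 carbon, 1 nitrogen, 1 sulfur; no ring), on an amine nitrogen). This change makes compound 3 share its ethylcarbamoyl group with compound 1, while keeping the methoxy group of compound 2. Both measured numbers are low and close together, and nothing measured points to a large move in either direction. The expected step of a number 5.4 percentage points lower from compound 2 to compound 3 (within the scatter) is small, and within the scatter. Compound 3 is therefore expected to give 20% in this assay, estimated between 8% and 32%.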

Compound 3, a percentage reported as inhibition, at one concentration (the size of the read-out at that concentration, not a potency): 26.6%
Compound 3: middle estimate off by 6.6 percentage points, on the low side, and the stated range covers the measured number.
By their numbers in this assay, from the lowest: compounds 1, 2 and 3 (each within the scatter of the next).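

In this assay the series now has its first steps that differ in one place: ethylcarbamoyl in place of the group of 6 heavy atoms (4 carbon, 1 nitrogen, 1 sulfur) on an amine nitrogen gives a number 1.2 percentage points higher from compound 2 to compound 3 (within the scatter) and methoxy in place of hydrogen on an aromatic carbon gives a number 8.3 percentage points higher from compound 1 to compound 3 (within the scatter) at the single concentration tested. Neither change separates its pair, so at this read-out the sulfur-bearing group and ethylcarbamoyl cannot be told apart, and neither can methoxy and hydrogen on the aromatic carbon. No measured evidence bears on the reason for either step.

The step from compound 2 to compound 3 alters the heteroatom and the carbon count of the group together, so an ethylthiocarbamoyl group on the same amine nitrogen would be needed to read the two apart. On these data alone, whether any group at either place can move the number beyond the scatter stays open, for instance a longer chain such as butylcarbamoyl on the amine nitrogen, or a chlorine or a carboxylic acid on the aromatic carbon that carries methoxy in compound 3.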